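Swapping a Methylamino for a Pyrrolidine Ring

The source may hold more compounds than are shown below. What is called first, only, known or untested is meant among the compounds shown, and "the series" means these compounds.

compound 1 (`CNc1nc(NC)nc(NC2(C#N)CCCCC2)n1`): 210 mL/min/kg
compound 2 (`CCCC(C#N)(CCC)Nc1nc(NC)nc(-n2cncn2)n1`): 32 mL/min/kg

In an ADME assay on microsomes from liver (Rattus norvegicus) for metabolic stability (a lower number here means slower removal, a higher number faster removal of the compound), compound 1 stands at 210 mL/min/kg and is the higher of the two measured compounds. Compound 2 gives 32 mL/min/kg and lies well below it, a gap beyond the usual scatter of repeated measurements. For the measured compounds named here, two numbers make a thin base, and no two measured compounds differ in just one place, so no measured step shows what a single change does here.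

The next compound is compound 3 (`CNc1nc(NC2(C#N)CCCCC2)nc(N2CCCC2)n1`). It keeps the rest of compound 1 but carries pyrrolidin-1-yl in place of methylamino on an aromatic carbon. The group that leaves and the group that enters are both joined to the core through nitrogen, and the other methylamino group stays.

Going by the values given here, with no measured step to lean on, the safest expectation in this assay is little movement, and the expected step is a 1.2-fold lower number from compound 1 to compound 3 (0.07 log units; within the scatter) (none beyond the scatter). For compound 3 the estimated clearance is 180 mL/min/kg (expected range 70 mL/min/kg to 400 mL/min/kg).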

Compound 3, clearance: > 276 mL/min/kg
Compound 3: no number, only a limit (the forecaster's own chance of this, stated with the estimate: 10%); middle value at least 1.5-fold (0.18 log units) from the limit.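

For the compounds shown here, this is the first measured change at a single place: putting pyrrolidin-1-yl in place of methylamino on an aromatic carbon, opposite the ring nitrogen, gives an at least 1.3-fold higher number from compound 1 to compound 3 (0.11 log units; that floor lies within the scatter). The reading for compound 3 in this assay is a limit of the assay and not a number: the limit of > 276 mL/min/kg in this assay, at which 1 of the 3 values shown sits. So the result gives no sign that this larger ring, which has no hydrogen-bond donor, slows removal at this position, although the part of the step that can be read does not by itself show a real rise.

Going by these compounds, how far compound 3 truly lies past its limit stays open, and so does the real size of this step, which could be small or large. Also open, on these data alone, is whether a dimethylamino group or a morpholin-4-yl ring at the same place, or a second pyrrolidin-1-yl in place of the remaining methylamino group, would give numbers closer to compound 1 or to compound 3.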